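The compounds below may be only part of what the source reports. "The series", "measured", "known", "first", "only" and "open" are said of these compounds alone.

Measured so far:
- compound 1, `Fc1ccc(CSc2nnc(-c3cnccn3)s2)c(F)c1`: 9630 nM
- compound 2, `Clc1ccccc1CSc1nnc(-c2cnccn2)n1-c1ccccc1`: 18800 nM

Both numbers come from a functional assay on HepG2 cells (Homo sapiens) for antiproliferative activity, read by MTT assay, with a stated time of 48 h; on this read-out higher numbers stand for weaker inhibition and lower numbers for stronger inhibition. Compound 2 holds the higher of the two values, but its nearest neighbour, compound 1, sits within the scatter of it, so the two cannot be ordered against each other. Compound 1 and compound 2 also differ in more than one place, so nothing is known about a single step between them.

Compound 3, `Fc1ccc(CSc2nnc(-c3cnccn3)n2-c2ccccc2)c(F)c1`, is not yet measured. It keeps the core of compound 2 and changes only the group on the chain carbon bound to the sulfur: 2,4-difluorophenyl in place of 2-chlorophenyl on a saturated chain carbon bound to a sulfur. Within the data shown here, the entering group is the one carried by compound 1, whose value in this assay lies within the scatter of that of compound 2. Among the measured compounds shown here, no measured pair isolates this change, so no size can be read from the data; a step from compound 2 to compound 3 of a 1.3-fold lower number from compound 2 to compound 3 (0.13 log units; within the scatter) is expected, that is none beyond the scatter, with the scatter itself allowed in both directions.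

For compound 3 a value of 14000 nM is estimated, within a range of 5000 nM to 40000 nM.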

Compound 3, half-maximal inhibitory concentration: 10400 nM
Compound 3: middle estimate off by 1.3-fold (0.13 log units), on the high side; the range from low to high includes it.
By their numbers in this assay, from the lowest: compounds 1, 3 and 2 (each within the scatter of the next).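

In this assay, among these compounds, putting 2,4-difluorophenyl in place of 2-chlorophenyl on a saturated chain carbon bound to a sulfur gives a 1.8-fold lower number from compound 2 to compound 3 (0.26 log units; within the scatter) as the first single-place step. The earlier compounds shown here offered no such pair, and this one now shows that the two groups cannot be told apart at this position on the core of compound 2, even though the change swaps one chlorine for two fluorines and adds a heavy atom to the group. Nothing measured here bears on why the step is this small, and no supporting evidence accompanies the result.

The compounds shown leave open whether any change at this position can move the number beyond the scatter, since both groups compared are halogenated phenyl rings of the same heavy-atom class and similar size. An amine, a carboxylic acid or a longer chain in place of the 2,4-difluorophenyl group would test that question, and the same 2-chlorobenzyl to 2,4-difluorobenzyl change on a different core would show whether this result holds beyond the core of compound 2.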